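A few compounds are considered here, and "the series" means these few. Any claim that something is new, unique, unknown or untested is made for them only; others in the source may bear on it.

Measured so far in a functional assay on COLO 205 cells (Homo sapiens) for cytotoxicity, read by MTT assay, with a stated time of 72 h; a lower number here means a stronger inhibitor, a higher number a weaker inhibitor:
Compound 1 `COc1ccc(C(=O)c2cc(OC)c(OC)c(OC)c2)cc1NC(=O)/C=C/c1cc(OC)c(OC)c(OC)c1` gives 5200 nM.
Compound 2 `COc1ccc(/C=C/C(=O)Nc2cc(C(=O)c3cc(OC)c(OC)c(OC)c3)ccc2OC)cc1` gives 10900 nM.
Compound 3 `C#CCOc1cccc(/C=C/C(=O)Nc2cc(C(=O)c3cc(OC)c(OC)c(OC)c3)ccc2OC)c1` gives 13400 nM.

Compound 3 carries the highest of these three numbers: the gap a 1.2-fold higher number from compound 2 to compound 3 (0.09 log units; within the scatter) is within the scatter, whereas a 2.6-fold higher number from compound 1 to compound 3 (0.41 log units; beyond the scatter) lies beyond it. Compound 4 `COc1ccc(C(=O)c2cc(OC)c(OC)c(OC)c2)cc1NC(=O)/C=C/c1ccc(F)cc1` differs from compound 3 by 4-fluorophenyl in place of 3-(propargyloxy)phenyl on a double-bonded chain carbon bound to a double-bonded chain carbon. Among the compounds with values here, the steps that bear on this change, a 2.1-fold higher number from compound 1 to compound 2 (0.32 log units; beyond the scatter) and a 2.6-fold higher number from compound 1 to compound 3 (0.41 log units; beyond the scatter), were both modest, and a 1.2-fold higher number from compound 2 to compound 3 (0.09 log units; within the scatter) stayed within the scatter, so three different groups at this place gave numbers in a narrow band. In this assay the expected change is therefore small and of uncertain direction, a 1.1-fold lower number from compound 3 to compound 4 (0.05 log units; within the scatter). Compound 4 is estimated at 12000 nM, between 6000 nM and 25000 nM.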

Compound 4, half-maximal inhibitory concentration: 3400 nM
Compound 4: the middle estimate sits 3.5-fold (0.55 log units) above what was measured; the measured number lies below the stated range.
By their numbers in this assay, from the lowest: compounds 4 and 1 (each within the scatter of the next); then compounds 2 and 3 (each within the scatter of the next).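

In this assay this place on a double-bonded chain carbon is less indifferent than the first three compounds suggested: 4-fluorophenyl in place of 3-(propargyloxy)phenyl gives a 3.9-fold lower number from compound 3 to compound 4 (0.60 log units; beyond the scatter). Fluoro in place of methoxy on an aromatic carbon gives a 3.2-fold lower number from compound 2 to compound 4 (0.51 log units; beyond the scatter), so a change of one group on that ring is enough to move the number beyond the scatter. 4-Fluorophenyl and 3,4,5-trimethoxyphenyl stand level, with a 1.5-fold lower number from compound 1 to compound 4 (0.18 log units; within the scatter), and nothing measured here accounts for these steps. The compounds shown leave open whether fluoro itself matters, as plain phenyl, 4-chlorophenyl and 4-aminophenyl do not appear among them.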